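This account rests on a few compounds, and the source may have more. Where it says the series, first, only, none or still open, it means among the compounds named here.

Compound 1 `COc1cc(-c2nn(-c3cccc(NC(=O)Nc4cc(C(F)(F)F)cc(C(F)(F)F)c4)c3)cc2-c2ccncc2)ccc1Cl`: 2570 nM
Compound 2 `COc1cc(-c2nn(-c3cccc(NC(=O)Nc4ccc(Cl)c(Cl)c4)c3)cc2-c2ccncc2)ccc1Cl`: > 50000 nM
Compound 3 `O=C(Nc1cccc(-n2cc(-c3ccncc3)c(-c3ccc(Cl)c(O)c3)n2)c1)Nc1ccc(Cl)c(Cl)c1`: > 32500 nM

Among the compounds with values here, in a functional assay on SK-OV-3 cells (Homo sapiens) for inhibition, read by sulforhodamine B assay, with a stated time of 48 h (a lower number here means a stronger inhibitor of growth, a higher number a weaker inhibitor of growth), compound 1 gives 2570 nM, the only plain number among the three. For compound 2 the value is a limit of the assay, (the limit of > 50000 nM in this assay, at which 1 of the 3 values shown sits). For compound 3 the value is likewise a limit of the assay, (the limit of > 32500 nM in this assay, at which 1 of the 3 values shown sits). The change from compound 2 to compound 3 is hydrogen in place of methyl on an oxygen on an aromatic ring, and the step it made is a step that the two limits leave unreadable from compound 2 to compound 3. How the core of compound 1 differs from that of compound 2 is not broken down here. Compound 4 `O=C(Nc1cccc(-n2cc(-c3ccncc3)c(-c3ccc(Cl)c(O)c3)n2)c1)Nc1cc(C(F)(F)F)cc(C(F)(F)F)c1` arises from compound 1 by the same change, (hydrogen in place of methyl on an oxygen on an aromatic ring). Since the measured step cannot be read, the expectation rests on compound 1 with its 2570 nM. The step from compound 1 to compound 4 is expected to be small, a 1.6-fold higher number from compound 1 to compound 4 (0.19 log units; within the scatter). Compound 4 is therefore estimated at 4000 nM, between 1500 nM and 15000 nM.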

Compound 4, concentration for total growth inhibition: 3810 nM
Beside the measured number, compound 4's estimate is 1.0-fold (0.02 log units) above it, and the stated range covers the measured number.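

In this assay the change from methoxy to hydroxy gives a 1.5-fold higher number from compound 1 to compound 4 (0.17 log units; within the scatter) and so makes no clear difference on the core of compound 1. On the core of compound 2 the same change joins two limits of the assay and its step cannot be read, so this single readable pair does not show that the change carries from one core to another. Nothing measured here gives a reason for this result.

Open, on these data alone, is whether a longer chain on that oxygen, such as ethyl or propyl, would read the same as methyl or hydrogen. Also open, as far as these compounds go, is whether an amine in place of the hydroxy would leave the number within the scatter on either core.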